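Indole replacement at the enamine nitrogen of compound 3

The source may hold more compounds than are shown below. What is called first, only, known or untested is meant among the compounds shown, and "the series" means these compounds.

Compound 3 `O=C(/C=C\Nc1ccc(Cl)cc1)c1nc(-c2ccc(F)cc2)n2ccccc12` gives 7030 nM in a functional assay on BT-474 cells (Homo sapiens) for cytotoxicity, read by MTT assay, with a stated time of 48 h (on this read-out higher numbers stand for weaker inhibition and lower numbers for stronger inhibition), the lowest of the two numbers on hand. Compound 1 `O=C(/C=C\Nc1ccc(F)cc1)c1nc(-c2ccc(F)cc2)n2ccccc12` gives 16900 nM in this assay. Compound 2 `COc1ccc(N/C=C\C(=O)c2nc(-c3ccc(F)cc3)n3ccccc23)cc1OC` reaches only the limit > 30000 nM in this assay, a limit and not a number (the limit of > 30000 nM in this assay, at which 1 of the 3 values shown sits). The steps measured so far are a 2.4-fold lower number from compound 1 to compound 3 (0.38 log units; beyond the scatter), an at least 1.7-fold higher number from compound 1 to compound 2 (0.24 log units; that floor lies within the scatter) and an at least 4.2-fold lower number from compound 2 to compound 3 (0.63 log units; beyond the scatter).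

Compound 4 `Cc1cc2cc(N/C=C\C(=O)c3nc(-c4ccc(F)cc4)n4ccccc34)ccc2[nH]1` is not yet measured. Relative to compound 3 the change is 2-methyl-1H-indol-5-yl in place of 4-chlorophenyl on an amine nitrogen. Within the data shown here, no measured pair exchanges a halophenyl for a bicyclic group on this nitrogen, so the closest guides are the swaps of aryl group on the same nitrogen, where the dimethoxyphenyl analogue sat weakest and the chlorophenyl analogue strongest. A move away from the chlorophenyl is therefore expected to give a somewhat higher number, estimated as a 1.4-fold higher number from compound 3 to compound 4 (0.15 log units; within the scatter), without confidence in the size. Compound 4 is estimated at 10000 nM in this assay, between 3500 nM and 30000 nM.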

Compound 4, half-maximal inhibitory concentration: > 30000 nM
Compound 4: no number, only a limit (the forecaster's own chance of this, stated with the estimate: 15%); middle value at least 3.0-fold (0.47 log units) away from the limit.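

Compound 4 gives > 30000 nM in this assay, a limit and not a number. On this amine nitrogen, 2-methyl-1H-indol-5-yl in place of 4-chlorophenyl gives an at least 4.2-fold higher number from compound 3 to compound 4 (0.63 log units; beyond the scatter), so a second group besides 3,4-dimethoxyphenyl now loses ground against 4-chlorophenyl, while the same exchange for 4-fluorophenyl gives only an at least 1.7-fold higher number from compound 1 to compound 4 (0.24 log units; that floor lies within the scatter). The step between compound 2 and compound 4 cannot be read, and both now sit at the top of the readable range: the limit of > 30000 nM in this assay, at which 2 of the 4 values shown sit.

Still open, on these data alone, is whether the loss belongs to the indole as a whole or to its methyl, which a plain 1H-indol-5-yl would test. Also open, as far as these compounds go, is whether the trend from fluoro to chloro continues with a 4-bromophenyl on this nitrogen.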